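Working notes: 3,5-dichlorophenyl on the series

The source may hold more compounds than are shown below. What is called first, only, known or untested is meant among the compounds shown, and "the series" means these compounds.

Measured so far in a functional assay (aorta) for inhibition, with Rattus norvegicus as the target; a lower number here means a stronger inhibitor, a higher number a weaker inhibitor:
- compound 1 `CNc1nsc(-c2ccc(N3CCN(c4cccc(C(F)(F)F)c4)CC3)nn2)n1` gives 3 nM
- compound 2 `Cc1nsc(-c2ccc(N3CCN(c4cccc(C#N)c4)CC3)nn2)n1` gives 3 nM

Compound 2 stands level with compound 1, within the scatter. Compound 3 `Cc1nsc(-c2ccc(N3CCN(c4cc(Cl)cc(Cl)c4)CC3)nn2)n1`, not yet measured, has 3,5-dichlorophenyl in place of 3-cyanophenyl on an amine nitrogen in a ring here. Among the measured compounds shown here, no measured step between compounds differing in one place is available, so the expectation rests only on compound 1 at 3 nM and compound 2 at 3 nM together. The expected step of a 1.7-fold higher number from compound 2 to compound 3 (0.22 log units; within the scatter) in this assay stays within the scatter, with any drift towards weaker inhibition. For compound 3 the estimate is 5 nM, with an expected range from 1.5 nM to 20 nM overall.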

Compound 3, half-maximal inhibitory concentration: < 0.1 nM
Compound 3 ended at the assay's limit; the forecaster's own chance of this, stated with the estimate: 3%; middle value at least 50-fold (1.69 log units) from the limit.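

Replacing 3-cyanophenyl with 3,5-dichlorophenyl on an amine nitrogen in a ring gives an at least 30-fold lower number from compound 2 to compound 3 (1.47 log units; beyond the scatter) in this assay, so this position responds strongly to the group it carries, which the earlier values could not show. The value of compound 3 is a limit of the assay: < 0.1 nM. The full size of the step therefore stays unread: the limit of < 0.1 nM in this assay, at which 1 of the 3 values shown sits.

As far as these compounds go, whether 3-chlorophenyl alone or 3,5-dimethylphenyl would give a similar step remains open. Also open, from the compounds shown here alone, is whether the change carries over to the methylamino-bearing core of compound 1.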